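Swapping Nitro for Fluoro in a Cell Test

A few compounds are considered here, and "the series" means these few. Any claim that something is new, unique, unknown or untested is made for them only; others in the source may bear on it.

Compound 1 `CC(=NNC(=S)Nc1ccccc1F)c1ccccn1`: 5 nM
Compound 2 `CC(=NNC(=S)Nc1cccc([N+](=O)[O-])c1)c1ccccn1`: 69 nM

In a functional assay on U-87MG ATCC cells (Homo sapiens) for cytotoxicity, read by MTT assay, with a stated time of 48 h (a higher number here means a weaker inhibitor, a lower number a stronger inhibitor), compound 2 gives 69 nM, the higher of the two numbers and a gap beyond the usual scatter. Compound 3 `CC(=NNC(=S)Nc1cccc(F)c1)c1ccccn1` has fluoro in place of nitro on an aromatic carbon, meta to a large group (fluoro in place of nitro on an aromatic carbon). A move toward a stronger inhibitor is expected, with a 4.6-fold lower number from compound 2 to compound 3 (0.66 log units; beyond the scatter) as the estimated step, because compound 1 with its fluoro group gives 5 nM. Among the measured compounds shown here, that is only one comparison, so the range stays wide. For compound 3 the estimated value is 15 nM, with an expected range from 3 nM to 60 nM.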

Compound 3, half-maximal inhibitory concentration: 18 nM
Estimate against measurement, compound 3: 1.2-fold (0.08 log units) below, and the stated range covers the measured number.
By their numbers in this assay, from the lowest: compound 1; then compound 3; then compound 2.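

In this assay, among the compounds shown here, fluoro in place of nitro on this aromatic carbon, meta to a large group, gives a 3.8-fold lower number from compound 2 to compound 3 (0.58 log units; beyond the scatter) as the first direct comparison at a single site. Nitro is not needed here for a low number, and fluoro, with only 1 heavy atom against the 3 of nitro, serves better at this position. Nothing measured here explains the step. Going by these compounds, whether an amine or a methoxy group on this carbon would give a lower or higher number stays open. So does whether the same exchange gives a similar step on other ring carbons.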